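The source may hold more compounds than are shown below. What is called first, only, known or untested is meant among the compounds shown, and "the series" means these compounds.

Compound 2 `O=C(O)CCc1ccc(OCC2COc3ccc(Cl)cc3O2)cc1F` gives the lower of the two numbers measured here. For the measured compounds named here, in a functional assay on HEK293 cells for agonist activity at Free fatty acid receptor 1 (Homo sapiens), read by fluorescence and calcium flux, with a stated time of 10 min (on this read-out lower numbers stand for smaller maximal responses and higher numbers for larger maximal responses), compound 1 `COc1ccc2c(c1)OC(COc1ccc(CCC(=O)O)c(F)c1)CO2` reaches 80%, while compound 2 reaches 50%, the only measured step being a number 30 percentage points lower from compound 1 to compound 2 (beyond the scatter). Compound 3 `O=C(O)CCc1ccc(OCC2COc3ccc(Br)cc3O2)cc1F` has not yet been measured. It differs from compound 2 by bromo in place of chloro on an aromatic carbon. Going by the values given here, no measured step exchanges one halogen for another, so the sole step at hand is the one from compound 1 to compound 2, which does not bear on this change directly; it only shows that the position tolerates a halogen at some cost to the maximal response. Because compound 2 stands at 50%, the expectation is that compound 3 stays near it, with a step of no change at the digits printed from compound 2 to compound 3 (within the scatter) that is not expected to exceed the scatter. Compound 3 is therefore estimated at 50%, in a range from 30% to 72%.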

Compound 3, largest response reached (Emax), in percent of the reference or control that the assay uses: 81%
Beside the measured number, compound 3's estimate is 31 percentage points below it, outside the stated range (above it).
By their numbers in this assay, from the lowest: compound 2; then compounds 1 and 3 (each within the scatter of the next).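

Changing a single halogen on this aromatic carbon is not a neutral exchange in this assay: the swap of chloro for bromo gives a number 31 percentage points higher from compound 2 to compound 3 (beyond the scatter) and so undoes the whole loss that chloro had seemed to suggest for a halogen at this place. The exchange of methoxy for bromo gives a number 1 percentage points higher from compound 1 to compound 3 (within the scatter) on the same carbon, so the lower response belongs to the chloro compound alone, not to halogens as a class. The data shown offer no explanation for the gap between the two halogens.

On these data alone, it remains open how a fluoro or an iodo group would behave on this carbon. An amine or a nitrile there is equally unsettled, so it cannot yet be said whether chloro is an isolated low point among substituents at this position.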